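From Furan to Naphthalene on the Shared Core

The compounds below may be only part of what the source reports. "The series", "measured", "known", "first", "only" and "open" are said of these compounds alone.

In an assay for inhibition of Thromboxane-A synthase (Homo sapiens), using microsomes (on this read-out higher numbers stand for weaker inhibition and lower numbers for stronger inhibition), compound 1 `N#Cc1ccc(C2OCC(C/C=C\CCC(=O)O)C(c3cccnc3)O2)cc1` gives 24 nM and compound 2 `O=C(O)CC/C=C\CC1COC(c2ccc([N+](=O)[O-])cc2)OC1c1cccnc1` gives 39 nM. Compound 3 `O=C(O)CC/C=C\CC1COC(c2ccco2)OC1c1cccnc1` gives 164 nM, the highest number of the three; the steps of a 6.8-fold higher number from compound 1 to compound 3 (0.83 log units; beyond the scatter) and a 4.2-fold higher number from compound 2 to compound 3 (0.62 log units; beyond the scatter) both lie beyond the scatter. Compound 4 `O=C(O)CC/C=C\CC1COC(c2cccc3ccccc23)OC1c1cccnc1` differs from compound 3 in one place: naphthalen-1-yl in place of furan-2-yl on a saturated ring carbon. Among the compounds with values here, no measured step involves a naphthalen-1-yl group, so only the two steps just named bear on this change, and both show the furan-2-yl group giving weaker inhibition than a 4-cyanophenyl or 4-nitrophenyl group on the same saturated ring carbon. The step of a 3.6-fold lower number from compound 3 to compound 4 (0.56 log units; beyond the scatter) is therefore expected in this assay. For compound 4 the estimate in this assay is 45 nM, expected to fall between 12 nM and 160 nM.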

Compound 4, half-maximal inhibitory concentration: 40 nM
Compound 4: the middle estimate sits 1.1-fold (0.05 log units) above what was measured; the measured number falls inside the stated range.
By their numbers in this assay, from the lowest: compounds 1, 2 and 4 (each within the scatter of the next); then compound 3.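

At the saturated ring carbon between two ring oxygen atoms, this assay now shows that the furan-2-yl loss can be regained by a group carrying neither nitrile nor nitro: a 4.1-fold lower number from compound 3 to compound 4 (0.61 log units; beyond the scatter). The naphthalen-1-yl group stands level with both substituted phenyl groups, with a 1.0-fold higher number from compound 2 to compound 4 (0.01 log units; within the scatter) and a 1.7-fold higher number from compound 1 to compound 4 (0.22 log units; within the scatter), so among these compounds neither substituent is required at this position. No measurement at hand accounts for these steps. The compounds shown leave open whether an unsubstituted phenyl or a naphthalen-2-yl group would match compound 4 here, and whether a saturated cyclohexyl group would give a number nearer that of compound 3.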